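The compounds below may be only part of what the source reports. "The series", "measured", "known", "first", "only" and "open" are said of these compounds alone.

Compound 3 `Cc1ccc2[nH]c(=O)c(CN(Cc3ccco3)C(=O)c3ccc(Cl)cc3)cc2c1` gives only a limit in an ADME assay on MT2 cells (Homo sapiens) for cytotoxicity, read by XTT assay, with a stated time of 4 days (on this read-out lower numbers stand for higher toxicity in this test and higher numbers for lower toxicity in this test), reported as > 61400 nM; that limit is the limit of > 61400 nM in this assay, at which 1 of the 3 values shown sits. Compound 1 `Cc1cccc2cc(CN(Cc3ccco3)C(=O)c3ccccc3F)c(=O)[nH]c12` likewise reaches a limit in this assay, reported as > 64000 nM. Compound 2 `Cc1ccc(C(=O)N(Cc2ccco2)Cc2cc3cccc(C)c3[nH]c2=O)cc1` gives a number in this assay, 9200 nM. Among the measured compounds shown here, the single measured step, an at least 6.9-fold lower number from compound 1 to compound 2 (0.84 log units; beyond the scatter), is the only one that turns a limit into a number, and it concerns the ring on the carbonyl carbon.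

Compound 4 `Cc1ccc2[nH]c(=O)c(CN(Cc3ccco3)C(=O)c3ccc(Br)cc3)cc2c1` differs from compound 3 by bromo in place of chloro on an aromatic carbon, the ring on the carbonyl going from 4-chlorophenyl to 4-bromophenyl. For the measured compounds named here, no measured step exchanges one halogen for another, so the step from compound 1 to compound 2 bears on it only loosely, as a change on the same ring. Compound 3 sits at a limit, and the exchange is small, so compound 4 is expected to remain at or close to that limit. The expected step of an at least 1.0-fold lower number from compound 3 to compound 4 (0.01 log units; that floor lies within the scatter) is estimated to lie within the scatter. Compound 4 is thus expected to give about 60000 nM, within 25000 nM to 150000 nM.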

Compound 4, half-maximal cytotoxic concentration: > 55400 nM
Compound 4: no number, only a limit; the forecaster's own chance of this, stated with the estimate: 65%; the middle value does not contradict the limit.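

In this assay, among the compounds shown here, compound 3 and compound 4 both give only limits, and no step between them can be read. The compounds shown leave open whether bromo and chloro on this ring differ at all in this read-out, and what number either compound would give.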